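The source may hold more compounds than are shown below. What is called first, only, known or untested is meant among the compounds shown, and "the series" means these compounds.

In a functional assay on cells (Homo sapiens) for cytotoxicity, read by resazurin assay, with a stated time of 72 h (a lower number here means a stronger inhibitor, a higher number a weaker inhibitor), two esters of the shared core have been measured so far. Compound 1 (`COc1cc(/C=C/C(=O)OCCCCCCO[N+](=O)[O-])ccc1O`) reads > 50000 nM and this is a limit of the assay, not a number, as the limit of > 50000 nM in this assay, at which 1 of the 2 values shown sits, records for this pair. Among the compounds with values here, compound 2 (`COc1cc(/C=C/C(=O)OCCCCCO[N+](=O)[O-])ccc1O`) reads 24900 nM and holds the only true number so far, so it cannot yet be ranked against any other measured value. Compound 3 (`COc1cc(/C=C/C(=O)OCCCO[N+](=O)[O-])ccc1O`) differs from compound 2 by nitrooxy in place of 2-(nitrooxy)ethyl on a saturated chain carbon, three bonds along the chain from an oxygen next to a carbonyl group with nitrooxy in place of 2-(nitrooxy)ethyl on a saturated chain carbon, three bonds along the chain from an oxygen next to a carbonyl group. Within the data shown here, one measured step bears on this change, and it also concerns the nitrooxy chain: an at least 2.0-fold lower number from compound 1 to compound 2 (0.30 log units; that floor lies within the scatter) is only a floor, and that floor lies within the scatter. A single step of that kind gives no firm direction, so no shift beyond the scatter is expected in this assay and a reading at the limit remains possible. The expected change is a 1.1-fold higher number from compound 2 to compound 3 (0.05 log units; within the scatter) and it is estimated to stay within the scatter. Compound 3 is estimated at 28000 nM with an expected range from 10000 nM to 60000 nM in this assay's terms.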

Compound 3, half-maximal inhibitory concentration: 39400 nM
The estimate for compound 3 lay 1.4-fold (0.15 log units) below the measured number, within the range that was stated.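

In this assay, nitrooxy in place of 2-(nitrooxy)ethyl on a saturated chain carbon, three bonds along the chain from an oxygen next to a carbonyl group, gives a 1.6-fold higher number from compound 2 to compound 3 (0.20 log units; within the scatter), so this change now has two true numbers behind it and still moves the reading by no more than the scatter. At the same place, nitrooxy in place of 3-(nitrooxy)propyl gives an at least 1.2-fold lower number from compound 1 to compound 3 (0.10 log units; that floor lies within the scatter), and since this is only a floor, it sets no direction for the change. Compound 1 remains a limit of the assay and not a number, so the three chains shown give no firm order: the limit of > 50000 nM in this assay, at which 1 of the 3 values shown sits.

The compounds shown leave open whether any change to this chain can move the reading in this assay beyond the scatter, as they include neither a longer chain than that of compound 1 nor a shorter one than that of compound 3. They also leave open what an amine or a carboxylic acid at the end of the chain, in place of the nitrooxy group, would do to the reading.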